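Chain extension in a hydroxamic acid series on colon cancer cells

The source may hold more compounds than are shown below. What is called first, only, known or untested is meant among the compounds shown, and "the series" means these compounds.

Measured so far:
Compound 1 `Cc1ccc(OCCCCN(Cc2ccc(C(=O)NO)cc2)c2ncc(-c3ccc(C)cc3)s2)cc1`: 580 nM
Compound 2 `CCCCN(Cc1ccc(C(=O)NO)cc1)c1ncc(-c2ccc(C)cc2)s1`: 8780 nM

In a functional assay on HCT-116 cells (Homo sapiens) for antiproliferative activity, read by MTT assay, with a stated time of 48 h (a higher number here means a weaker inhibitor of growth, a lower number a stronger inhibitor of growth), compound 2 stands with the highest number of the two, its nearest neighbour being compound 1 with a much lower number. The single step shown, a 15-fold higher number from compound 1 to compound 2 (1.18 log units; beyond the scatter), links them: when hydrogen replaces the 4-methylphenoxy group at the chain end, the number rises sharply. Compound 3 `CCCCCCN(Cc1ccc(C(=O)NO)cc1)c1ncc(-c2ccc(C)cc2)s1` is the unmeasured compound; relative to compound 2 it carries ethyl in place of hydrogen on a saturated chain carbon, four bonds along the chain from a nitrogen on an aromatic ring. This change moves in the opposite direction to that step, putting carbon back onto the chain end where compound 1 held its aryl ether, but only as a short alkyl piece without the ring. The step from compound 1 to compound 2 is therefore the only one that bears on it, and its size suggests that part of the lost potency might return. Compound 3 is expected to show a moderate drop in number, a 2.5-fold lower number from compound 2 to compound 3 (0.40 log units; beyond the scatter), giving an estimate of 3500 nM, with a range of 1200 nM to 9000 nM.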

Compound 3, concentration for 50% growth inhibition: 4850 nM
For compound 3 the middle estimate is 1.4-fold (0.14 log units) below the measured one; the measured number falls inside the stated range.
By their numbers in this assay, from the lowest: compound 1; then compounds 3 and 2 (each within the scatter of the next).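

In this assay, ethyl on this chain carbon gives a 1.8-fold lower number from compound 2 to compound 3 (0.26 log units; within the scatter) and, as that step is within the scatter, lengthening the chain by this short alkyl piece does not set the two compounds apart. The other new step is larger and lies beyond the scatter: it reads an 8.4-fold higher number from compound 1 to compound 3 (0.92 log units; beyond the scatter) and shows that at this position an ethyl end does not stand in for the 4-methylphenoxy end. No measurement offered here explains either step.

The compounds shown leave open whether a longer chain such as octyl would separate from the short alkyl ends. They also leave open which part of the 4-methylphenoxy group carries the difference, as a plain phenyl, a phenoxy without the methyl, or a terminal amine could show.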